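Methyl Branching on Two Different Chains of Bile Acid Receptor Antagonists

A few compounds are considered here, and "the series" means these few. Any claim that something is new, unique, unknown or untested is made for them only; others in the source may bear on it.

Three compounds have been measured in an assay on isolated protein for antagonist activity at Bile acid receptor (Homo sapiens), read by HTRF, with a stated time of 30 min; on this read-out lower numbers stand for stronger inhibition and higher numbers for weaker inhibition:

Compound 1, `CCC(=O)c1cc(CC)c(OCCCCCC(C)(C)c2nnn[nH]2)cc1O`, gives 8500 nM.
Compound 2, `CCc1cc(C(=O)C(C)C)c(O)cc1OCCCCCC(C)(C)c1nnn[nH]1`, gives 8600 nM.
Compound 3, `CCCc1cc(C(C)=O)c(O)cc1OCCCCCC(C)(C)c1nnn[nH]1`, gives 25200 nM.

Compound 1 and compound 2 share one core and differ only by methyl in place of hydrogen on a saturated chain carbon bound to a carbonyl carbon and a saturated chain carbon. That change produced a 1.0-fold higher number from compound 1 to compound 2 (0.01 log units; within the scatter), so the added methyl at this place made no measurable difference in this assay. Compound 3 carries the same atoms as compound 1 joined differently; the difference between the two cores is not broken down here. Among the three numbers, compound 3 stands highest, and its gap to both compound 1 and compound 2 is beyond the usual scatter.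

Compound 4, `CC(=O)c1cc(CC(C)C)c(OCCCCCC(C)(C)c2nnn[nH]2)cc1O`, has not yet been measured. It differs from compound 3 by methyl in place of hydrogen on a saturated chain carbon bound to two saturated chain carbons. Among the measured compounds shown here, this is the same kind of change as the one from compound 1 to compound 2, but not the same: there the methyl entered on a saturated chain carbon bound to a carbonyl carbon and a saturated chain carbon, here it enters on a saturated chain carbon bound to two saturated chain carbons. For the measured compounds named here, with only one precedent, the expectation rests on that single step: because the earlier methyl gave a 1.0-fold higher number from compound 1 to compound 2 (0.01 log units; within the scatter), a similarly small step is expected, a 1.1-fold lower number from compound 3 to compound 4 (0.02 log units; within the scatter). Compound 4 is therefore estimated at 24000 nM in this assay, with a likely range from 11000 nM to 52000 nM.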

Compound 4, half-maximal inhibitory concentration: 5800 nM
Compound 4: the middle estimate sits 4.1-fold (0.62 log units) above what was measured, and the stated range ends above it.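

In this assay, replacing a hydrogen with a methyl turned the propyl group of compound 3 into the isobutyl group of compound 4, and this gave a 4.3-fold lower number from compound 3 to compound 4 (0.64 log units; beyond the scatter), a modest but real gain for so small an addition. A methyl in place of a hydrogen therefore cannot be treated as a change with one fixed effect in this series, since the two examples give clearly different results: the same change on two cores in this assay, a 1.0-fold higher number (0.01 log units; within the scatter) from compound 1 to compound 2 and a 4.3-fold lower number (0.64 log units; beyond the scatter) from compound 3 to compound 4, 4.4-fold (0.64 log units) apart, beyond the scatter of two such steps. This does not show why the results differ, since the two methyls sit at different places, one on a saturated chain carbon bound to a carbonyl carbon and a saturated chain carbon and the other on a saturated chain carbon bound to two saturated chain carbons, and the cores differ too, so two steps cannot separate the effect of place from that of core, and they set no rule for other compounds.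

The compounds shown leave open whether the gain continues with a longer chain, such as pentyl, or with a cyclohexyl group in place of the isobutyl group. They also leave open whether a carboxylic acid could stand in for the group at the far end of the long chain that all these compounds share.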